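The source may hold more compounds than are shown below. What is called first, only, known or untested is meant among the compounds shown, and "the series" means these compounds.

Compound 2 `COc1cccc(CNCCCNc2ccnc3cc(Oc4ccc(F)cc4)ccc23)c1O` is one of three compounds with a permeability result. In an ADME assay for permeability, using PAMPA, with a stated time of 30 min, at pH 7.4 (on this read-out lower numbers stand for lower permeability and higher numbers for higher permeability), compound 2 gives 317 10^-6 cm/s. Compound 1 `COc1cccc(Oc2ccc3c(NCCCNCc4cc(F)ccc4OC)ccnc3c2)c1` gives 317 10^-6 cm/s in this assay, and compound 3 `Fc1ccc(Oc2ccc3c(NCCCNCc4ccco4)ccnc3c2)cc1` gives 317 10^-6 cm/s, so compound 2 stands level with both of them at the digits shown, and no ordering among the three can be drawn.

Compound 4 `COc1cccc(CNCCCNc2ccnc3cc(Cc4ccc(F)cc4)ccc23)c1O` has not yet been measured. It differs from compound 2 in one place: 4-fluorobenzyl in place of 4-fluorophenoxy on an aromatic carbon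

Among the compounds with values here, only one measured step is available, and it concerns a different part of the molecule: the exchange of the group on the saturated chain carbon bound to an amine nitrogen gave no change at the digits printed from compound 2 to compound 3 (within the scatter). Within the data shown here, no measured step touches the aromatic carbon where compound 4 changes, so the expectation for compound 4 rests mainly on how uniform the three values are in this assay. Compound 4 is expected to give about 317 10^-6 cm/s, within a range from 160 10^-6 cm/s to 500 10^-6 cm/s. That estimate corresponds to an expected step of no change at the digits printed from compound 2 to compound 4 (within the scatter), that is, none beyond the scatter.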

Compound 4, apparent permeability: 23 10^-6 cm/s
Compound 4: middle estimate off by 14-fold (1.14 log units), on the high side; the measured number lies below the stated range.
By their numbers in this assay, from the lowest: compound 4; then compounds 1, 2 and 3 (each within the scatter of the next).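

In this assay, within the data shown here, the exchange on this aromatic carbon gives a 14-fold lower number from compound 2 to compound 4 (1.14 log units; beyond the scatter), whereas the one change read earlier, on the saturated chain carbon, gave no change at the digits printed from compound 2 to compound 3 (within the scatter). This aromatic carbon is thus the only place among the compounds shown where a single exchange moves the read-out beyond the scatter, even though 4-fluorophenoxy and 4-fluorobenzyl have the same heavy-atom count and differ in that the first holds an oxygen and a hydrogen-bond acceptor. Nothing available bears on the reason for this drop.

Going by these compounds, it remains open whether another group on this aromatic carbon, such as an amine or a 4-fluorophenylthio group, would read closer to compound 2 or to compound 4. Also open, on these data alone, is whether the same exchange would give a step of similar size with the furan-2-yl group of compound 3 on the chain.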